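Amino for Methoxy on the Aryl Partner of Compound 1

The source may report more compounds than this note shows. Statements on the series, on what has been measured and on what is new or still open speak of the compounds shown alone.

Compound 1 `COc1ccc(-n2ncnc2-c2cc(OC)c(OC)c(OC)c2)cc1` is the only one of the three measured compounds that returns a number in a functional assay on K562 cells (Homo sapiens) for antiproliferative activity, read by MTT assay, with a stated time of 72 h (a lower number here means a stronger inhibitor, a higher number a weaker inhibitor), where compound 1 gives 3600 nM. Compound 2 `COc1cc(-n2ncnc2-c2ccc(F)cc2)cc(OC)c1OC` reaches only a limit in this assay, with > 10000 nM. Compound 3 `COc1cc(-n2ncnc2-c2cccc(Cl)c2)cc(OC)c1OC` also reaches only a limit in this assay, with > 10000 nM. The step from compound 2 to compound 3 is a step that the two limits leave unreadable from compound 2 to compound 3, so it says nothing about changes on that ring; both compounds sit at the limit of > 10000 nM in this assay, at which 2 of the 3 values shown sit. Compound 4 `COc1cc(-c2ncnn2-c2ccc(N)cc2)cc(OC)c1OC` differs from compound 1 by amino in place of methoxy on an aromatic carbon. Among the compounds with values here, no measured step bears on this change, so nothing beyond the usual scatter is expected, the estimated step being a 1.2-fold lower number from compound 1 to compound 4 (0.08 log units; within the scatter). Compound 4 is therefore expected to give 3000 nM in this assay, between 900 nM and 10000 nM.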

Compound 4, half-maximal inhibitory concentration: > 10000 nM
Compound 4: a limit, no number (the forecaster's own chance of this, stated with the estimate: 25%); middle value at least 3.3-fold (0.52 log units) away from the limit.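

Going from 4-methoxyphenyl to 4-aminophenyl gives an at least 2.7-fold higher number from compound 1 to compound 4 (0.44 log units; beyond the scatter) in this assay and leaves the compounds shown without any number but that of compound 1. Within the data shown here, this is the only readable step among them, and it shows that this position, on an aromatic carbon para to a large group, responds to a change of group. As far as these compounds go, whether a hydroxyl, a dimethylamino group or an acetamide in this place would return a number stays open. Compound 4 gives only a limit, so how far it truly lies from compound 1 also stays open: the limit of > 10000 nM in this assay, at which 3 of the 4 values shown sit.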